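The source may report more compounds than this note shows. Statements on the series, on what has been measured and on what is new or still open speak of the compounds shown alone.

Compound 2, with structure `Nc1nc(SC2CCCC2)c2ncn(/C=C3/CC3(CO)CO)c2n1`, has been tested in an ADME assay on Akata cells (Homo sapiens) for cytotoxicity, with a stated time of 7 days; on this read-out lower numbers stand for higher toxicity in this test and higher numbers for lower toxicity in this test. In this assay compound 2 gives > 20000 nM, which is a limit of the assay rather than a number. Compound 1, with structure `CCOc1nc(N)nc2c1ncn2/C=C1/CC1(CO)CO`, shares the core and carries an ethoxy group where compound 2 carries cyclopentylsulfanyl. In this assay compound 1 gives > 20000 nM, again a limit of the assay. For the measured compounds named here, the only measured step, a step that the two limits leave unreadable from compound 1 to compound 2, therefore cannot be read in size or direction. Compound 3, with structure `CC(C)Sc1nc(N)nc2c1ncn2/C=C1/CC1(CO)CO`, differs from compound 2 by isopropyl in place of cyclopentyl on a sulfur. Going by the values given here, no measured step bears directly on this change; the only guidance is the limit of > 20000 nM in this assay, at which 2 of the 2 values shown sit, where both values sit. Compound 3 is therefore expected to give a result near or beyond that same limit, with a step that the limit leaves unreadable from compound 2 to compound 3 not readable beyond the scatter. The estimate for compound 3 is 30000 nM, in a range from 12000 nM to 80000 nM.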

Compound 3, half-maximal cytotoxic concentration: > 20000 nM
Compound 3: a limit, no number; the forecaster's own chance of this, stated with the estimate: 80%; the middle value is on the limit's open side.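

No step between compound 1, compound 2 and compound 3 can be read in this assay, since each result is a limit and not a number: the limit of > 20000 nM in this assay, at which 3 of the 3 values shown sit.

The compounds shown leave open how toxic each one is in this test and whether changing the sulfur or ethoxy group alters that toxicity.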